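Selenium-linked bis-amide series: methyl to benzyl step

A few compounds are considered here, and "the series" means these few. Any claim that something is new, unique, unknown or untested is made for them only; others in the source may bear on it.

Measured so far:
compound 1 `C[Se]/C(=N\C(=O)c1cccs1)NC(=O)c1cccs1` — > 100000 nM
compound 2 `CS/C(=N\C(=O)c1csc([N+](=O)[O-])c1)NC(=O)c1csc([N+](=O)[O-])c1` — > 100000 nM
compound 3 `O=C(/N=C(/NC(=O)c1cnc2ccccc2c1)[Se]Cc1ccccc1)c1cnc2ccccc2c1` — > 100000 nM

All three measured compounds were run in a functional assay on HT-29 cells (Homo sapiens) for cytotoxicity, read by MTT assay, with a stated time of 72 h; on this read-out higher numbers stand for lower toxicity in this test and lower numbers for higher toxicity in this test. For compound 1 the value > 100000 nM is a limit of the test, not a number. Compound 2 likewise returns only the limit > 100000 nM. Compound 3 also stops at the limit > 100000 nM. So compound 1 stands at the same limit as every other compound measured here, and nothing separates the three on the numbers shown; this is summed up in the limit of > 100000 nM in this assay, at which 3 of the 3 values shown sit. Among the compounds with values here, no step between measured compounds can be computed, as no two of them differ in a single place.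

Compound 4 `O=C(/N=C(/NC(=O)c1cccs1)[Se]Cc1ccccc1)c1cccs1` is the next compound to be read in this assay. It differs from compound 1 by phenyl in place of hydrogen on a saturated chain carbon bound to a selenium atom. Compound 3 carries the same selenium-bound benzyl group on a different pair of amide carbonyls and sits at the limit, so the step from compound 1 to compound 4 is expected to show no change beyond the scatter, with compound 4 expected to come back as a limit as well, estimated as a step that the limit leaves unreadable from compound 1 to compound 4. Compound 4 is expected to give 150000 nM, within 50000 nM to 500000 nM.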

Compound 4, concentration lethal to 50% of the cells: > 100000 nM
Compound 4: only a limit was reported; the forecaster's own chance of this, stated with the estimate: 85%; the middle value lies beyond the limit too.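

The step between compound 1 and compound 4, methyl to benzyl, cannot be read, as both compounds return only a limit of the test and no number: the limit of > 100000 nM in this assay, at which 4 of the 4 values shown sit.

The compounds shown leave open whether phenyl in place of hydrogen on a saturated chain carbon bound to a selenium atom changes cytotoxicity at all.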